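The compounds below may be only part of what the source reports. "The series", "measured", "known", "first", "only" and "open" are said of these compounds alone.

Of the compounds shown here, three of a shared core have been measured in an ADME assay on SK-OV-3 cells (Homo sapiens) for cytotoxicity, read by sulforhodamine B assay, with a stated time of 48 h, tested at 10 uM; a lower number here means less inhibition, a higher number more inhibition at the concentration tested (going by the name of the read-out). Compound 1, `CCCCCCCCc1cn(C(c2ccccc2)c2cc3cc(Br)ccc3nc2OC)nn1`, gives 2.06%. Compound 2, `COc1nc2ccc(Br)cc2cc1C(c1ccccc1)n1cc(CCO)nn1`, gives 8.46%. Compound 3, `COc1nc2ccc(Br)cc2cc1C(c1ccccc1)n1cc(CO)nn1`, gives 3.23%, which is the second highest of the three numbers; its nearest neighbour is compound 1 and its furthest is compound 2, and both gaps lie within the scatter. The steps among these compounds are all small: a number 6.4 percentage points higher from compound 1 to compound 2 (within the scatter), a number 1.2 percentage points higher from compound 1 to compound 3 (within the scatter), and a number 5.2 percentage points lower from compound 2 to compound 3 (within the scatter).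

Compound 4, `COc1nc2ccc(Br)cc2cc1C(c1ccccc1)n1cc(-c2ccccc2C(F)(F)F)nn1`, has not yet been measured in this assay. It differs from compound 3 in one place: 2-(trifluoromethyl)phenyl in place of hydroxymethyl on an aromatic carbon

Among the measured compounds shown here, none of the measured steps exchanges a hydroxymethyl for an aromatic ring; the closest in kind are the step from compound 1 to compound 3 and the step from compound 2 to compound 3, in which an octyl-type chain or a hydroxymethyl gives way to hydroxy, each within the scatter. For the measured compounds named here, with every measured step in this assay lying within the scatter and no step of the new kind in hand, no movement beyond the scatter is expected, so the step of a number 2.8 percentage points higher from compound 3 to compound 4 (within the scatter) is an estimate of little change. Compound 4 is therefore expected to give about 6%, within a range from -3% to 22%.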

Compound 4, a percentage reported as inhibition, at one concentration (the size of the read-out at that concentration, not a potency): 9.55%
The estimate for compound 4 lay 3.6 percentage points below the measured number; low and high end bracket the measured number.
By their numbers in this assay, from the lowest: compounds 1, 3, 2 and 4 (each within the scatter of the next).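

Among the compounds shown here, at the aromatic carbon of the five-membered ring, the earlier compounds carried only saturated chains, whereas compound 4 places an aromatic ring there, and in this assay its 2-(trifluoromethyl)phenyl group gives a number 6.3 percentage points higher from compound 3 to compound 4 (within the scatter) against hydroxymethyl, a number 1.1 percentage points higher from compound 2 to compound 4 (within the scatter) against 2-hydroxyethyl and a number 7.5 percentage points higher from compound 1 to compound 4 (within the scatter) against octyl. This extends the flat picture from chains of different length to a group that brings a six-membered aromatic ring and three fluorine atoms and has no hydrogen-bond donor or acceptor: even this larger exchange, with 10 heavy atoms entering in place of 2 in the step from compound 3, does not move the number in this assay beyond the scatter. No measurement is at hand that could account for these numbers or tie them to any property of the groups.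

The compounds shown leave open whether any group at this position can move the number beyond the scatter, for instance a plain phenyl without the trifluoromethyl, an amine or a carboxylic acid on the chain. They also leave open whether changes elsewhere on the shared core, such as replacing the bromine or the methoxy group, would do so.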